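Adding a chloro group to the fluorophenyl arm of compound 1

The source may hold more compounds than are shown below. What is called first, only, known or untested is meant among the compounds shown, and "the series" means these compounds.

Compound 1 `COc1nc(-c2cccc(F)c2)ccc1[C@@H](c1ccccc1)[C@@](O)(CCN(C)C)c1cccc2ccccc12` is the reference point. In a toxicity assay on HeLa cells (Homo sapiens) for cytotoxicity (on this read-out higher numbers stand for lower toxicity in this test and lower numbers for higher toxicity in this test), compound 1 gives 62.8 ug/mL, the highest of the two plain numbers shown. Compound 2 `COc1nc(-c2ccc(C(F)(F)F)cc2)ccc1[C@@H](c1ccccc1)[C@@](O)(CCN(C)C)c1cccc2ccccc12` is recorded in this assay only as a limit of the assay, > 64 ug/mL. Within the data shown here, compound 3 `COc1nc(-c2ccncc2)ccc1[C@@H](c1ccccc1)[C@@](O)(CCN(C)C)c1cccc2ccccc12` gives 9.6 ug/mL in this assay, and the step of a 6.5-fold lower number from compound 1 to compound 3 (0.82 log units; beyond the scatter) is the one change that clearly moved the number. The step of an at least 1.0-fold higher number from compound 1 to compound 2 (0.00 log units; that floor lies within the scatter) stayed within the scatter, as the limit of > 64 ug/mL in this assay, at which 1 of the 3 values shown sits, shows.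

Compound 4 `COc1nc(-c2ccc(Cl)c(F)c2)ccc1[C@@H](c1ccccc1)[C@@](O)(CCN(C)C)c1cccc2ccccc12` differs from compound 1 by one change: chloro in place of hydrogen on an aromatic carbon, so that 3-fluorophenyl becomes 4-chloro-3-fluorophenyl. Like compound 2, it keeps a substituted benzene ring rather than swapping it for pyridin-4-yl as compound 3 does, so the small step of an at least 1.0-fold higher number from compound 1 to compound 2 (0.00 log units; that floor lies within the scatter) is the closer guide. I expect the step of a 1.1-fold lower number from compound 1 to compound 4 (0.06 log units; within the scatter) to stay within the scatter. For compound 4 I estimate 55 ug/mL in this assay, with a likely range from 25 ug/mL to 64 ug/mL.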

Compound 4, half-maximal cytotoxic concentration: > 64 ug/mL
Compound 4: no number, only a limit; the forecaster's own chance of this, stated with the estimate: 35%; middle value at least 1.1-fold (0.06 log units) away from the limit.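

In this assay compound 4 is recorded only as a limit of the assay, > 64 ug/mL. Chloro in place of hydrogen, ortho to a fluoro group and para to a large group, gives an at least 1.0-fold higher number from compound 1 to compound 4 (0.00 log units; that floor lies within the scatter), so this ring carbon takes the added atom with no sign of higher toxicity in this test. The new benzene arm and pyridin-4-yl also stand clearly apart, with an at least 6.6-fold higher number from compound 3 to compound 4 (0.82 log units; beyond the scatter), so among these compounds the clearly lower number remains with compound 3 alone.

Going by these compounds, how compound 2 and compound 4 compare cannot be read, because both stop at the same limit: the limit of > 64 ug/mL in this assay, at which 2 of the 4 values shown sit. Whether an amine or a carboxylic acid in place of the chloro would bring the number down, as the pyridin-4-yl arm of compound 3 does, stays open.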